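Trifluoromethyl to Chloro on a Shared Core

The source may hold more compounds than are shown below. What is called first, only, known or untested is meant among the compounds shown, and "the series" means these compounds.

Of the compounds shown here, two built on the same core have been tested in a functional assay on UACC-257 cells (Homo sapiens) for inhibition, read by sulforhodamine B assay, with a stated time of 48 h; on this read-out lower numbers stand for stronger inhibition of growth and higher numbers for weaker inhibition of growth. Compound 1 `COc1cc2cc(Oc3ccc(NC(=O)Nc4cccc(C(F)(F)F)c4)cc3)c(C)nc2cc1OC` gives 3660 nM, and compound 2 `COc1cc2cc(Oc3ccc(NC(=O)Nc4ccc(Cl)c(C(F)(F)F)c4)cc3)c(C)nc2cc1OC` gives 2360 nM. Among the measured compounds shown here, the one measured step, a 1.6-fold lower number from compound 1 to compound 2 (0.19 log units; within the scatter), means that compound 2 holds the lower of the two numbers, yet it sits within the scatter of compound 1, so the two cannot be told apart on this evidence.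

Compound 3 `COc1cc2cc(Oc3ccc(NC(=O)Nc4ccc(Cl)c(Cl)c4)cc3)c(C)nc2cc1OC` is the next step from compound 2: chloro in place of trifluoromethyl on an aromatic carbon. For the measured compounds named here, this swap has no measured counterpart here. Going by the values given here, the single step seen so far, a 1.6-fold lower number from compound 1 to compound 2 (0.19 log units; within the scatter), concerns a different change and was itself within the scatter, so it offers no direction for the present one. Among the compounds with values here, with no bearing precedent, the expectation is that compound 3 stays close to compound 2. The step is expected to be a 1.1-fold higher number from compound 2 to compound 3 (0.03 log units; within the scatter). In this assay compound 3 is estimated at 2500 nM, with a range from 1000 nM to 6500 nM.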

Compound 3, concentration for total growth inhibition: 6280 nM
Compound 3: the middle estimate sits 2.5-fold (0.40 log units) below what was measured; the range from low to high includes it.
By their numbers in this assay, from the lowest: compounds 2, 1 and 3 (each within the scatter of the next, the first and the last beyond it).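

In this assay, among the compounds shown here, the step of a 2.7-fold higher number from compound 2 to compound 3 (0.43 log units; beyond the scatter) is the first one to lie beyond the scatter, so the group on this aromatic carbon, ortho to a chloro group, does make a measurable difference, and the pair with trifluoromethyl and chloro there can be told apart. The difference is modest, and the other new step, a 1.7-fold higher number from compound 1 to compound 3 (0.23 log units; within the scatter), stays within the scatter, so compound 1 and compound 3 cannot be told apart even though 3,4-dichlorophenyl stands in place of 3-(trifluoromethyl)phenyl on the amide-type nitrogen. No supporting measurement is available to explain the difference between compound 2 and compound 3.

The compounds shown leave open whether a methyl group, a methoxy group or a nitrile on this same aromatic carbon would give a number closer to that of compound 2 or to that of compound 3. They also leave open whether swapping trifluoromethyl for chloro would give a step of similar size in a compound that carries a hydrogen, rather than a chloro group, on the neighbouring carbon.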